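Trimming one fluorine from a difluorophenyl hydrazone

A few compounds are considered here, and "the series" means these few. Any claim that something is new, unique, unknown or untested is made for them only; others in the source may bear on it.

Measured so far:
- Compound 1 `COc1ccc(OC)c(/C=N/NC(=O)c2cc(OC)c(OC)c(OC)c2)c1` — 51.7%
- Compound 2 `COc1cc(C(=O)N/N=C/c2ccccc2F)cc(OC)c1OC` — 81.8%
- Compound 3 `COc1cc(C(=O)N/N=C/c2ccc(F)c(F)c2)cc(OC)c1OC` — 43.7%

All three share the same core and differ only in the ring attached to the carbon with a double bond to nitrogen. In a functional assay on PC-3 cells (Homo sapiens) for antiproliferative activity, read by MTT assay, tested at 5 uM (on this read-out higher numbers stand for a stronger effect at the one concentration tested and lower numbers for a weaker effect), compound 3 gives 43.7%, the lowest of the three numbers. Compound 1 gives 51.7%, which lies within the scatter of compound 3, so the two cannot be ordered. Compound 2 gives 81.8%, clearly above both.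

Compound 4 `COc1cc(C(=O)N/N=C/c2cccc(F)c2)cc(OC)c1OC` differs from compound 3 in one place: hydrogen in place of fluoro on an aromatic carbon

Going by the values given here, only one measured step touches this region of the molecule, a number 38.1 percentage points lower from compound 2 to compound 3 (beyond the scatter). That step changed both the number of fluoro groups and where they sit, so it does not isolate the effect of removing a single fluoro. Compound 4 keeps one fluoro, as compound 2 does, but not at the same position, so compound 2 is only a loose guide.

The expected change is therefore a moderate rise, part of the way back toward compound 2, with wide uncertainty: a number 14.3 percentage points higher from compound 3 to compound 4 (beyond the scatter). Compound 4 is estimated at 58%, within 38% to 80%.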

Compound 4, a percentage reported as inhibition, at one concentration (the size of the read-out at that concentration, not a potency): 64.1%
For compound 4 the middle estimate is 6.1 percentage points below the measured one, and the stated range covers the measured number.
By their numbers in this assay, from the lowest: compounds 3 and 1 (each within the scatter of the next); then compound 4; then compound 2.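

In this assay, trading one fluoro group for hydrogen, so that 3,4-difluorophenyl becomes 3-fluorophenyl, gives a number 20.4 percentage points higher from compound 3 to compound 4 (beyond the scatter), which shows that this single change is enough on its own to move the number beyond the scatter. The other new step, a number 17.7 percentage points lower from compound 2 to compound 4 (beyond the scatter), keeps one fluoro group on the ring and changes only where it sits, so among these compounds the place of the fluoro counts as well as the number of fluoro groups, two things the earlier step between the 2-fluorophenyl and 3,4-difluorophenyl compounds could not separate. Nothing available explains why either step goes the way it does.

The compounds shown leave open how a phenyl ring carrying no fluoro group at all would compare, and whether a chloro group, a hydroxyl group or an amine in the same place would track with fluoro. Since each number comes from a single concentration, they also leave open how these compounds would rank across a range of concentrations.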